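A few compounds are considered here, and "the series" means these few. Any claim that something is new, unique, unknown or untested is made for them only; others in the source may bear on it.

Measured compounds:
- compound 1 `CCC1=C(O)c2c(oc(-c3ccc(O)cc3)cc2=O)C(CC)(CC)C1=O`: in a functional assay on KBVIN cells (Homo sapiens) for antiproliferative activity, read by sulforhodamine B assay, with a stated time of 3 days (on this read-out lower numbers stand for an effect already at smaller amounts and higher numbers for an effect only at larger amounts of compound), compound 1 gives 20.6 uM
- compound 2 `CCOc1ccc(-c2cc(=O)c3c(o2)C(CC)(CC)C(=O)C(CC)=C3O)cc1`: compound 2 gives 7.54 uM
- compound 3 `CCC1=C(O)c2c(oc(-c3ccc(O)c(C)c3C)cc2=O)C(CC)(CC)C1=O`: compound 3 gives 2.75 uM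

Within this set compound 2 stands second highest of the three numbers, with compound 1 nearest and compound 3 furthest from it. The step to the unmeasured compound 4 `CCC1=C(O)c2c(oc(-c3cc(C)c(O)c(C)c3)cc2=O)C(CC)(CC)C1=O` is 4-hydroxy-3,5-dimethylphenyl in place of 4-ethoxyphenyl on an aromatic carbon.

Among the measured compounds shown here, two measured steps bear on it. The change from the ethoxy compound back to the free phenol is given, in reverse, by a 2.7-fold lower number from compound 1 to compound 2 (0.44 log units; beyond the scatter), so removing the ethyl alone would be expected to raise the number. Adding two methyl groups to the hydroxyphenyl ring is given by a 7.5-fold lower number from compound 1 to compound 3 (0.87 log units; beyond the scatter), and the net change from the ethoxy compound to the dimethyl phenol by a 2.7-fold lower number from compound 2 to compound 3 (0.44 log units; beyond the scatter). For the measured compounds named here, compound 4 carries the methyl groups at different positions than compound 3, and no measured pair shows that pattern, so the expected step is taken as smaller than that from compound 2 to compound 3 and with wider uncertainty. The expected step is a 1.9-fold lower number from compound 2 to compound 4 (0.28 log units; within the scatter). Compound 4 is therefore estimated at 4 uM in this assay, with a range from 1.5 uM to 12 uM.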

Compound 4, concentration for half-maximal effect: 8.9 uM
For compound 4 the middle estimate is 2.2-fold (0.35 log units) below the measured one; the measured number falls inside the stated range.
By their numbers in this assay, from the lowest: compound 3; then compounds 2 and 4 (each within the scatter of the next); then compound 1.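

In this assay, the arrangement of the two methyl groups on the hydroxyphenyl ring matters, with a 3.2-fold higher number from compound 3 to compound 4 (0.51 log units; beyond the scatter) when 4-hydroxy-3,5-dimethylphenyl replaces 4-hydroxy-2,3-dimethylphenyl on the same aromatic carbon. The 3,5-dimethyl pattern still improves on the unsubstituted phenol, with a 2.3-fold lower number from compound 1 to compound 4 (0.36 log units; beyond the scatter), yet it does not separate from the ethyl ether, with a 1.2-fold higher number from compound 2 to compound 4 (0.07 log units; within the scatter) and both numbers within the scatter. Nothing available on these compounds accounts for the difference between the two dimethyl patterns.

Open, going by these compounds, is whether a single methyl group on the hydroxyphenyl ring carries the gain seen with two. Also open, on these data alone, is how an amine in place of the hydroxyl, or an ethyl ether on either dimethyl phenol, would read here.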